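The compounds below may be only part of what the source reports. "The series", "measured", "known", "first", "only" and "open" are said of these compounds alone.

In a functional assay for inhibition, with Homo sapiens as the target (on this read-out higher numbers stand for weaker inhibition and lower numbers for stronger inhibition), compound 1 `C=CCn1ncc2c(CC)ncn2c1=O` is reported only as a limit, > 48000 nM. Compound 2 `C=CCn1ncc2cncn2c1=O` lacks the ethyl group that compound 1 carries; in this assay compound 2 likewise gives only a limit, > 48000 nM. The step that the two limits leave unreadable from compound 2 to compound 1 thus cannot be read, the change being (ethyl in place of hydrogen on an aromatic carbon). Compound 3 `CCc1nc(C)c2cnnc(O)n12` carries a different core; how it differs from the core of compound 2 is not broken down here. In this assay compound 3 also gives only a limit, > 48000 nM. Compound 4 `CCc1nnc(O)n2c(CC)nc(C)c12` arises from compound 3 by ethyl in place of hydrogen on an aromatic carbon. This is the same kind of change as that made from compound 2 to compound 1, though the place differs: in compound 1 the ethyl sits on a five-membered aromatic ring with 2 nitrogen, two ring bonds from the ring nitrogen, whereas in compound 4 it sits on a six-membered aromatic ring with 3 nitrogen, ortho to a fused ring and para to a hydroxy group. Among the measured compounds shown here, because of the limit of > 48000 nM in this assay, at which 3 of the 3 values shown sit, no measured step fixes the size of this change, and the step from compound 3 to compound 4 is estimated as a step that the limit leaves unreadable from compound 3 to compound 4. Compound 4 is accordingly expected near 60000 nM, within 20000 nM to 200000 nM.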

Compound 4, half-maximal inhibitory concentration: 24000 nM
Compound 4: the middle estimate sits 2.5-fold (0.40 log units) above what was measured; low and high end bracket the measured number.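

In this assay, ethyl in place of hydrogen on an aromatic carbon gives an at least 2.0-fold lower number from compound 3 to compound 4 (0.30 log units; that floor lies within the scatter), so on the core of compound 3 the change goes with a measurable value, but the floor of this step does not by itself clear the usual scatter. Among the compounds shown here, the same kind of change on the core of compound 2 gives a step that cannot be read, so the two cores offer no pair of sizes to compare, and nothing here shows that the change carries from one core to the other, where the ethyl also sits in a different place. The transfer stays unsettled because only one compound has left the limit: the limit of > 48000 nM in this assay, at which 3 of the 4 values shown sit.

From the compounds shown here alone, whether a longer chain, such as propyl, or an amine on the same aromatic carbon of the core of compound 3 would give a clearer step remains open. Going by these compounds, it is also open whether an ethyl on the core of compound 2 could give a readable step once a further group such as a carboxylic acid is present.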